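Bromo and Cyano Variations on a Fused Bicyclic Amide Core

This account rests on a few compounds, and the source may have more. Where it says the series, first, only, none or still open, it means among the compounds named here.

Compound 1 `NC(=O)c1cn2ccncc2n1` was tested in a functional assay on the whole organism for inhibition, with Cavia porcellus as the target; on this read-out lower numbers stand for an effect already at smaller amounts and higher numbers for an effect only at larger amounts of compound. For compound 1 the assay reports only a limit, > 56 nM. Compound 2 `NC(=O)c1cn2c(Br)cncc2n1`, which carries bromo in place of hydrogen on an aromatic carbon, gives 38 nM in this assay; the change made an at least 1.4-fold lower number from compound 1 to compound 2 (0.16 log units; that floor lies within the scatter). Compound 3 `N#Cc1cn2ccncc2n1` differs from compound 1 by cyano in place of carbamoyl on an aromatic carbon. For compound 3 this assay again reports only a limit, > 167 nM, so the step that the two limits leave unreadable from compound 1 to compound 3 cannot be read. Compound 4 `N#Cc1cn2c(Br)cncc2n1` is not yet measured; it bears the same change as compound 2, namely (bromo in place of hydrogen on an aromatic carbon). Because the measured step of an at least 1.4-fold lower number from compound 1 to compound 2 (0.16 log units; that floor lies within the scatter) ran toward lower numbers, the step of an at least 1.1-fold lower number from compound 3 to compound 4 (0.04 log units; that floor lies within the scatter) is expected in the same direction. Compound 4 is estimated at 150 nM, between 40 nM and 600 nM.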

Compound 4, concentration for half-maximal effect: > 15 nM
Compound 4 gave a limit, no number; the forecaster's own chance of this, stated with the estimate: 50%; the middle value lies beyond the limit too.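

Compound 4 gave only a limit in this assay, so its steps from compound 2 and from compound 3 cannot be read. From the compounds shown here alone, whether bromo in place of hydrogen changes the read-out of the cyano compounds stays open.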